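The source may hold more compounds than are shown below. What is called first, only, known or untested is meant among the compounds shown, and "the series" means these compounds.

Measured compounds:
compound 1 `O=C1NCCN(c2cccc(Cl)c2)N1`: 2100 nM
compound 2 `CSc1cccc(N2CCNC(=O)N2)c1`: 2200 nM
compound 3 `O=C1NCCN(c2ccccn2)N1`: 8600 nM

In a functional assay on cells for inhibition of Polyunsaturated fatty acid 5-lipoxygenase (Homo sapiens) (a lower number here means a stronger inhibitor, a higher number a weaker inhibitor), compound 3 gives the highest number of the three; compound 2 and compound 1 sit close together, and both lie clearly lower than compound 3. Compound 4 `COc1cccc(N2CCNC(=O)N2)n1` differs from compound 3 by methoxy in place of hydrogen on an aromatic carbon, next to the ring nitrogen. Within the data shown here, the only measured step, a 1.0-fold higher number from compound 1 to compound 2 (0.02 log units; within the scatter), is a swap of one group for another on a different core and says nothing about adding a methoxy. Among the measured compounds shown here, no measured step bears on this change, so no step beyond the scatter is expected, in either direction. Compound 4 is therefore estimated at 8000 nM, within 2500 nM to 25000 nM. This estimate means an expected step of a 1.1-fold lower number from compound 3 to compound 4 (0.03 log units; within the scatter).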

Compound 4, half-maximal inhibitory concentration: 3500 nM
The estimate for compound 4 lay 2.3-fold (0.36 log units) above the measured number; the range from low to high includes it.
By their numbers in this assay, from the lowest: compounds 1, 2 and 4 (each within the scatter of the next); then compound 3.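

Methoxy in place of hydrogen on an aromatic carbon next to the ring nitrogen gives a 2.5-fold lower number from compound 3 to compound 4 (0.39 log units; beyond the scatter) in this assay, the first measured effect of a change at this position. This carbon therefore accepts a group larger than hydrogen, and the number falls rather than rises. Nothing measured here explains the step. The compounds shown leave open whether methyl, an amine or a longer chain such as ethoxy on the same carbon would lower the number as well.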